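A Hydroxymethyl Group Added to the Core of Compound 1

The compounds below may be only part of what the source reports. "The series", "measured", "known", "first", "only" and "open" are said of these compounds alone.

Compound 1 `CC(C)=CCC[C@H](C)c1ccc(C)cc1O` is the starting point. In a functional assay on MCF7 cells (Homo sapiens) for inhibition, read by MTT assay, with a stated time of 72 h (on this read-out higher numbers stand for weaker inhibition and lower numbers for stronger inhibition), compound 1 gives only a limit, > 20000 nM, and not a number. Compound 1 therefore sits at the limit of > 20000 nM in this assay, at which 1 of the 2 values shown sits. A second compound, compound 2 `CCOC(CCN1COc2c([C@@H](C)CCC=C(C)C)ccc(C)c2C1)OCC`, is built differently and shares no single-change relation with compound 1; in this assay compound 2 gives 13200 nM, which is a number rather than a limit. Compound 3 `CC(C)=CCC[C@H](C)c1ccc(C)c(CO)c1O` has not been tested. It differs from compound 1 in one place: hydroxymethyl in place of hydrogen on an aromatic carbon. For the measured compounds named here, no measured pair shows what such a change does here, so there is no step to lean on. The step from compound 1 to compound 3 is expected to be a number no higher from compound 1 to compound 3 (the limit leaves the size open), which is none beyond the usual scatter. Compound 3 is thus estimated at 20000 nM, with a range from 7000 nM to 60000 nM.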

Compound 3, half-maximal inhibitory concentration: > 20000 nM
Compound 3 gave a limit, no number; the forecaster's own chance of this, stated with the estimate: 60%; the middle value sits exactly at the limit.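

In this assay, compound 1 and compound 3 both give a limit rather than a number, so no step can be read between them: the limit of > 20000 nM in this assay, at which 2 of the 3 values shown sit. As far as these compounds go, whether hydroxymethyl in place of hydrogen on an aromatic carbon changes inhibition at all, and by how much, stays open.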